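The compounds below may be only part of what the source reports. "The series", "measured", "known", "first", "only" and "open" are said of these compounds alone.

Values in an ADME assay on HeLa cells (Homo sapiens) for cytotoxicity, read by MTT assay; a higher number here means a weaker inhibitor, a lower number a stronger inhibitor:
- compound 1 `CCN(CC)C(=O)CCC(=O)Oc1ccc(C[C@H]2C(=O)OC[C@@H]2Cc2ccc(OC)c(OC)c2)cc1OC`: 213000 nM
- compound 2 `COc1ccc(C[C@H]2COC(=O)[C@@H]2Cc2ccc(OCc3cn(-c4ccc(Br)cc4)nn3)c(OC)c2)cc1OC`: 128000 nM
- compound 3 `COc1ccc(-n2cc(COc3ccc(C[C@H]4C(=O)OC[C@@H]4Cc4ccc(OC)c(OC)c4)cc3OC)nn2)cc1`: >= 600000 nM, a limit

Compound 3 has no exact number, only the limit >= 600000 nM. Compound 4 `COc1ccc(C[C@H]2COC(=O)[C@@H]2Cc2ccc(OCc3cn(-c4ccccc4)nn3)c(OC)c2)cc1OC` has hydrogen in place of methoxy on an aromatic carbon, para to a large group, turning 4-methoxyphenyl into phenyl (hydrogen in place of methoxy on an aromatic carbon). One measured step changes that same group: with methoxy in place of bromo, there is an at least 4.6-fold higher number from compound 2 to compound 3 (0.67 log units; beyond the scatter). Compound 4 loses that methoxy, so a move back towards compound 2 seems likely, though hydrogen is not bromo. The expected step is an at least 2.1-fold lower number from compound 3 to compound 4 (0.33 log units; beyond the scatter), towards a lower number. For compound 4, the estimate is 280000 nM, with an expected range of 110000 nM to 650000 nM.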

Compound 4, half-maximal inhibitory concentration: 124000 nM
Estimate against measurement, compound 4: 2.3-fold (0.35 log units) above; the measured number falls inside the stated range.
By their numbers in this assay, from the lowest: compounds 4, 2 and 1 (each within the scatter of the next). At a limit, above all of these: compound 3.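

In this assay, taking the methoxy off the 4-methoxyphenyl gives an at least 4.8-fold lower number from compound 3 to compound 4 (0.68 log units; beyond the scatter). The number for compound 3 is only a limit: the limit of >= 600000 nM in this assay, at which 1 of the 4 values shown sits. Hydrogen and bromo at this place read alike, with a 1.0-fold lower number from compound 2 to compound 4 (0.01 log units; within the scatter), and a wholly different group on the oxygen also reads alike, with a 1.7-fold lower number from compound 1 to compound 4 (0.23 log units; within the scatter), so among these compounds only the methoxy stands apart.

As far as these compounds go, whether an ethoxy, an amine or a carboxylic acid at this place would behave like methoxy or like hydrogen stays open. From the compounds shown here alone, the true size of the methoxy step also remains unknown.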